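A few compounds are considered here, and "the series" means these few. Any claim that something is new, unique, unknown or untested is made for them only; others in the source may bear on it.

Measured compounds:
compound 1, `O=C(CSc1nnc(-c2ccncc2)o1)N/N=C/c1ccc(Cl)cc1`: 20500 nM
compound 2, `Cc1ccc(/C=N/NC(=O)CSc2nnc(-c3ccncc3)o2)cc1`: 21800 nM
compound 3, `O=C(CSc1nnc(-c2ccncc2)o1)N/N=C/c1cc(Cl)ccc1O`: 5470 nM

In a functional assay on BGC-823 cells (Homo sapiens) for cytotoxicity, read by MTT assay, with a stated time of 48 h (on this read-out lower numbers stand for stronger inhibition and higher numbers for weaker inhibition), compound 3 gives the lowest number of the three. Compound 4 is `O=C(CSc1nnc(-c2ccncc2)o1)N/N=C/c1ccc(O)c(O)c1`; it carries 3,4-dihydroxyphenyl in place of 5-chloro-2-hydroxyphenyl on a carbon with a double bond to nitrogen. Going by the values given here, the steps that bear on this change, a 3.7-fold lower number from compound 1 to compound 3 (0.57 log units; beyond the scatter) and a 4.0-fold lower number from compound 2 to compound 3 (0.60 log units; beyond the scatter), show that a hydroxyl-bearing aryl gave a modest gain over aryls without one; no measured step tests a second hydroxyl or the loss of the chlorine. Compound 4 keeps a hydroxyl-bearing aryl, so its number is expected to stay near that of compound 3, with a step of a 1.3-fold higher number from compound 3 to compound 4 (0.11 log units; within the scatter), not clearly beyond the scatter in either direction. Compound 4 is therefore estimated at 7000 nM, within a range from 2500 nM to 20000 nM.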

Compound 4, half-maximal inhibitory concentration: 1260 nM
For compound 4 the middle estimate is 5.6-fold (0.74 log units) above the measured one, outside the stated range (below it).
By their numbers in this assay, from the lowest: compound 4; then compound 3; then compounds 1 and 2 (each within the scatter of the next).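

In this assay, going by these compounds alone, the aryl on the carbon with a double bond to nitrogen matters more than the earlier compounds showed: 3,4-dihydroxyphenyl brings a 4.3-fold lower number from compound 3 to compound 4 (0.64 log units; beyond the scatter) and so a chlorine is not needed for a low number. The gap to aryls without a hydroxyl is large, with a 16-fold lower number from compound 1 to compound 4 (1.21 log units; beyond the scatter) and a 17-fold lower number from compound 2 to compound 4 (1.24 log units; beyond the scatter) on the same read-out.

From the compounds shown here alone, whether the second hydroxyl or the loss of chlorine drives the gain stays open, as does whether an amine or a carboxylic acid on this ring would serve as well. No measurement here explains the gain.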